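The compounds below may be only part of what the source reports. "The series", "measured", "known", "first", "only" and "open" are said of these compounds alone.

Compound 1, `CC(=O)/C(=N\c1cccc(F)c1)NNc1ccccc1C`, gives 43 nM in an assay on isolated protein for binding affinity to corticotropin-releasing factor receptor 1 (Homo sapiens); on this read-out higher numbers stand for weaker inhibition and lower numbers for stronger inhibition. Compound 2, `CC(=O)/C(=N\c1cccc(C#N)c1)NNc1ccccc1C`, gives > 10000 nM, which is a limit of the assay and not a number. Compound 3, `CC(=O)/C(=N\c1cccc(F)c1)NNc1ccccc1C(F)(F)F`, gives 197 nM.

The three compounds share a core and differ at two places. From compound 1 to compound 2 the change is cyano in place of fluoro on an aromatic carbon, and the result is an at least 230-fold higher number from compound 1 to compound 2 (2.36 log units; beyond the scatter). From compound 1 to compound 3 the change is trifluoromethyl in place of methyl on an aromatic carbon, and the result is a 4.6-fold higher number from compound 1 to compound 3 (0.66 log units; beyond the scatter). Compound 3 therefore stands as the higher of the two numbers that were actually measured, while compound 2 reached only the limit, (the limit of > 10000 nM in this assay, at which 1 of the 3 values shown sits).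

Compound 4, `CC(=O)/C(=N\c1cccc(C#N)c1)NNc1ccccc1C(F)(F)F`, has not yet been measured. It differs from compound 3 by cyano in place of fluoro on an aromatic carbon. For the measured compounds named here, this is the same change as the one from compound 1 to compound 2, made at the same place, but on the core of compound 3 rather than that of compound 1. Since that earlier step already carried compound 2 past the limit of the assay, and since compound 3 starts from a higher number than compound 1, the step from compound 3 to compound 4 is expected to be large as well, of the order of a 200-fold higher number from compound 3 to compound 4 (2.31 log units; beyond the scatter), most likely ending again at a limit rather than at a number. For compound 4 the estimate is 40000 nM, somewhere between 5000 nM and 300000 nM.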

Compound 4, inhibition constant: > 10000 nM
Compound 4 ended at the assay's limit; the forecaster's own chance of this, stated with the estimate: 85%; the middle value lies beyond the limit too.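

Compound 4 gives > 10000 nM in this assay, which is a limit of the assay and not a number. Putting cyano in place of fluoro on the second core gives an at least 50-fold higher number from compound 3 to compound 4 (1.70 log units; beyond the scatter), so the large loss seen on the first core appears here too, although this rests on only two pairs of compounds and does not show that the loss has the same size on both cores: the same change on two cores in this assay, an at least 230-fold higher number (2.36 log units; beyond the scatter) from compound 1 to compound 2 and an at least 50-fold higher number (1.70 log units; beyond the scatter) from compound 3 to compound 4; the limit leaves it open whether they differ The step between the two cyano compounds, which would show what trifluoromethyl in place of methyl does in the cyano pair, cannot be read, and the assay gives no way to rank those two compounds against each other: the limit of > 10000 nM in this assay, at which 2 of the 4 values shown sit.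

The compounds shown leave open whether any group other than fluoro can sit at this place on the 3-fluorophenyl ring and keep the binding, for example chloro, methoxy, an amine or a carboxylic acid. They also leave open how groups such as ethyl or chloro would compare with methyl and trifluoromethyl on the other aromatic ring, and whether a change there could bring a cyano compound back within the range the assay can read.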